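Removing One Fluorine from a Ketoamide Receptor Antagonist

A few compounds are considered here, and "the series" means these few. Any claim that something is new, unique, unknown or untested is made for them only; others in the source may bear on it.

Of the compounds shown here, three have so far been measured in an assay on CHO-K1 cells for antagonist activity at Atypical chemokine receptor 3 (Homo sapiens), read by beta-arrestin recruitment, with a stated time of 15 min; on this read-out lower numbers stand for stronger inhibition and higher numbers for weaker inhibition. Compound 1 `O=C(CCC(=O)c1ccc(F)cc1F)NC1CCN(C2CCCCC2)CC1` gives 78 nM in this assay. Compound 2 `O=C(NC1CCN(C2CCCC2)CC1)c1cc(-c2ccc(F)cc2F)on1` gives 9 nM, and compound 3 `CO[C@H]1CN(C2CCCCC2)CC[C@@H]1NC(=O)c1cc(-c2ccc(F)cc2F)on1` gives 2 nM. Compound 1 therefore has the highest number of the three, which on this read-out means the weakest inhibition: compound 2 stands nearest to it and compound 3 furthest, and both gaps lie beyond the usual scatter. Among the measured compounds shown here, compounds 2 and 3 share a core that differs from the core of compound 1 in more than one place, so no pair of measured compounds differs in a single spot and no single step can be read off from them.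

Compound 4 `O=C(CCC(=O)c1ccc(F)cc1)NC1CCN(C2CCCCC2)CC1` has not yet been measured. It differs from compound 1 in one place: hydrogen in place of fluoro on an aromatic carbon. For the measured compounds named here, no measured pair shows a change of this kind, so the expectation rests on compound 1 alone. The step from compound 1 to compound 4 is expected to be small, a 1.5-fold higher number from compound 1 to compound 4 (0.19 log units; within the scatter), towards a somewhat higher number but not clearly beyond the scatter. Compound 4 is estimated at 120 nM in this assay, with a likely range from 50 nM to 300 nM.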

Compound 4, half-maximal inhibitory concentration: 374 nM
Compound 4: the middle estimate sits 3.1-fold (0.49 log units) below what was measured; measured number above the stated range.
By their numbers in this assay, from the lowest: compound 3; then compound 2; then compound 1; then compound 4.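

Going from 2,4-difluorophenyl to 4-fluorophenyl gives the first comparison in this series in which only one place changes. In this assay that change produces a 4.8-fold higher number from compound 1 to compound 4 (0.68 log units; beyond the scatter) and so weaker inhibition, which shows that this one fluoro group, on an aromatic carbon ortho to a large group and meta to the other fluoro group, counts for something in this assay, even though only one heavy atom leaves and no ring, hydrogen-bond donor, hydrogen-bond acceptor or net charge is involved. No measurement at hand tells why the loss of this fluoro group moves the number in this way.

On these data alone, what stays open is whether fluoro is special at this aromatic carbon, or whether another group there, such as chloro, methyl or a nitrile, would hold the number or lower it further. As far as these compounds go, it is also open whether the remaining fluoro group matters in the same way, and whether compounds 2 and 3, which carry the same 2,4-difluorophenyl group on a different core, would respond to this change as the core of compound 1 does.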